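This account rests on a few compounds, and the source may have more. Where it says the series, first, only, none or still open, it means among the compounds named here.

Going by the values given here, in an ADME assay on the whole organism (Mus musculus, strain CD1) for pharmacokinetics, read by LC-MS, with a stated time of 24 h, at a dose of 5 mg/kg by the oral route (on this read-out higher numbers stand for higher oral bioavailability and lower numbers for lower oral bioavailability), compound 1 `O=C(O)Cn1nc(Cc2nc3cc(Cl)c(OCC(F)F)cc3[nH]2)c2ccccc2c1=O` gives 4%, the lowest of the three numbers measured so far. Compound 2 `O=C(O)Cn1nc(Cn2cc3cc(OCC4CC4)c(Cl)cc3n2)c2ccccc2c1=O` gives 19% and compound 3 `CC(C(=O)O)c1nn(Cc2cn3cc(OCC4CC4)c(C(F)(F)F)cc3n2)c2ccccc2c1=O` gives 42%, both beyond the usual scatter from compound 1.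

The next compound, compound 4 `O=C(O)Cn1nc(Cc2nc3cc(Cl)c(OCC4CC4)cc3[nH]2)c2ccccc2c1=O`, keeps the core of compound 1 and changes in one place: cyclopropyl in place of difluoromethyl on a saturated chain carbon bound to an oxygen on an aromatic ring. Cyclopropyl stands in place of difluoromethyl on a saturated chain carbon bound to an oxygen on an aromatic ring, so 2,2-difluoroethoxy becomes cyclopropylmethoxy.

Among the compounds with values here, no two measured compounds differ in only one place, so the effect of this swap has not been seen directly. The only hints are indirect. Compound 2 also carries cyclopropylmethoxy and gives 19%, and compound 3 carries it too and gives 42%. Both differ from compound 1 elsewhere as well, so neither number can be credited to this group alone, and only a modest expectation is justified.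

The estimated step is a number 8 percentage points higher from compound 1 to compound 4 (within the scatter), a small rise that stays within the usual scatter. The expected value for compound 4 is 12%, with an estimated range from 4% to 28%.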

Compound 4, oral bioavailability: 2%
For compound 4 the middle estimate is 10 percentage points above the measured one; the measured number lies below the stated range.
By their numbers in this assay, from the lowest: compounds 4 and 1 (each within the scatter of the next); then compound 2; then compound 3.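

In this assay, going by these compounds alone, replacing 2,2-difluoroethoxy with cyclopropylmethoxy on the core of compound 1 gives a number 2 percentage points lower from compound 1 to compound 4 (within the scatter), the only reading so far of a single change on its own. On this read-out, then, cyclopropyl and difluoromethyl cannot be told apart at this place, on a saturated chain carbon bound to an oxygen on an aromatic ring, and on this core cyclopropylmethoxy alone does not bring a rise beyond the scatter. No measurement of a property of either group is available to account for this result.

Going by these compounds, it remains open whether a different kind of group at this place, such as an amine, a carboxylic acid or a longer chain, would shift the number beyond the scatter, or whether the same swap would behave alike on another core. Also open is which of the other features that set compound 2 and compound 3 apart from compound 1 goes with their higher numbers, as no pair shown differs in one of those places alone.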